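A few compounds are considered here, and "the series" means these few. Any claim that something is new, unique, unknown or untested is made for them only; others in the source may bear on it.

Measured compounds in the series:

- compound 1 `O=C1CSc2cc(OCc3ccc(Cl)cc3)ccc2N1`: 2.7 nM
- compound 2 `O=C1CSc2cc(OCc3ccc(Br)cc3)ccc2N1`: 4.1 nM
- compound 3 `O=C1CSc2cc(OCCCc3ccccc3)ccc2N1`: 20 nM

In an assay on isolated protein for inhibition of Amine oxidase [flavin-containing] B (Homo sapiens), read by fluorescence and spectrophotometry, with a stated time of 20 min (on this read-out lower numbers stand for stronger inhibition and higher numbers for weaker inhibition), compound 2 gives 4.1 nM, the second highest of the three numbers. Its nearest neighbour is compound 1: the step of a 1.5-fold higher number from compound 1 to compound 2 (0.18 log units; within the scatter) stays within the scatter, so the two cannot be ordered. For the measured compounds named here, its furthest neighbour is compound 3, which gives 20 nM in this assay; no single-point step links compound 3 to compound 2, so only the gap between the two values is known.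

Compound 4 `Cc1ccc(COc2ccc3c(c2)SCC(=O)N3)cc1` differs from compound 2 by methyl in place of bromo on an aromatic carbon. Going by the values given here, the only measured step at this same carbon is a 1.5-fold higher number from compound 1 to compound 2 (0.18 log units; within the scatter), an exchange of one such substituent for another that left the number within the scatter. Among the compounds with values here, no measured step covers methyl in place of bromo, so the expectation rests on that single swap and is loose. A step of no more than the scatter is expected, in either direction, with a slight lean toward a higher number for compound 4, meaning a 1.3-fold higher number from compound 2 to compound 4 (0.13 log units; within the scatter). Compound 4 is therefore estimated at 5.5 nM, with a range from 2 nM to 15 nM.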

Compound 4, half-maximal inhibitory concentration: 8.2 nM
Beside the measured number, compound 4's estimate is 1.5-fold (0.17 log units) below it, and the stated range covers the measured number.
By their numbers in this assay, from the lowest: compounds 1, 2 and 4 (each within the scatter of the next, the first and the last beyond it); then compound 3.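

In this assay, for the compounds shown here, this aromatic carbon, para to a large group, now has a third substituent: methyl in place of bromo gives a 2.0-fold higher number from compound 2 to compound 4 (0.30 log units; within the scatter) and methyl in place of chloro gives a 3.0-fold higher number from compound 1 to compound 4 (0.48 log units; beyond the scatter) as the first exchange here to pass beyond the scatter, though only modestly. The position is therefore not wholly indifferent to the substituent: chloro and methyl can be told apart, while bromo cannot be separated from either. Nothing available bears on why chloro and methyl part in this way.

As far as these compounds go, whether fluoro, methoxy, trifluoromethyl or an amine at this carbon would stay in the same range remains open. Compound 3 differs from the others in more than one place, which leaves the effect of its longer chain unseparated.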